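Chloro addition on the anilino ring: working notes

A few compounds are considered here, and "the series" means these few. Any claim that something is new, unique, unknown or untested is made for them only; others in the source may bear on it.

Measured so far in an assay on COS-7 cells for agonist activity at Free fatty acid receptor 1 (Homo sapiens), read by scintillation counting and inositol phosphate accumulation, with a stated time of 90 min; a higher number here means that more compound is needed for the effect, a lower number that less compound is needed:
compound 1, `Cc1cccc(Nc2nc(N)nc(COc3ccc4c(C)cc(=O)oc4c3)n2)c1`, gives 1780 nM
compound 2, `Cc1cc(Nc2nc(N)nc(COc3ccc4c(C)cc(=O)oc4c3)n2)ccc1Cl`, gives 240 nM
compound 3, `Cc1ccc(Nc2nc(N)nc(COc3cccc(N4CCCC4=O)c3)n2)cc1Cl`, gives 820 nM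

From compound 1 to compound 2 the change is chloro in place of hydrogen on an aromatic carbon; this gave a 7.4-fold lower number from compound 1 to compound 2 (0.87 log units; beyond the scatter). Compound 4, `Cc1ccc(Nc2nc(N)nc(COc3ccc(Cl)c(N4CCCC4=O)c3)n2)cc1Cl`, is not yet measured and differs from compound 3 by chloro in place of hydrogen on an aromatic carbon. The difference between the core of compound 1 and the core of compound 3 is not broken down here. The two changes are the same kind of change, not the same: in compound 2 the chloro sits ortho to a methyl group, in compound 4 ortho to a 2-oxopyrrolidin-1-yl group, on a different ring of the molecule. On that basis a smaller step is expected, a 3.3-fold lower number from compound 3 to compound 4 (0.52 log units; beyond the scatter), beside the earlier one in this assay. Compound 4 is estimated at 250 nM, between 80 nM and 800 nM.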

Compound 4, half-maximal effective concentration: 2450 nM
Estimate against measurement, compound 4: 9.8-fold (0.99 log units) below; the whole stated range lies below it.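

In this assay, chloro in place of hydrogen, ortho to a 2-oxopyrrolidin-1-yl group and para to a large group, gave a 3.0-fold higher number from compound 3 to compound 4 (0.48 log units; beyond the scatter). The same kind of change therefore does not carry from one core to the other in this series, and on these two cores it runs in opposite directions: the same change on two cores in this assay, a 7.4-fold lower number (0.87 log units; beyond the scatter) from compound 1 to compound 2 and a 3.0-fold higher number (0.48 log units; beyond the scatter) from compound 3 to compound 4, 22-fold (1.35 log units) apart, beyond the scatter of two such steps. This does not show what sets the two steps apart, since the chloro also sits on a different ring in each pair, and one step per core gives no rule for any further core.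

Still open, going by these compounds, is whether a fluoro or methoxy group at the chloro position of compound 4 would move the number the same way. On these data alone, it is also open whether a chloro on the same ring of the core of compound 1 would follow compound 4 or compound 2.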